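Bromo Addition in Two Hydroxybenzamide Cores: Macrophage Cytotoxicity

This account rests on a few compounds, and the source may have more. Where it says the series, first, only, none or still open, it means among the compounds named here.

Compound 1 `O=C(Nc1cc(C(F)(F)F)cc(C(F)(F)F)c1)c1ccccc1O` and compound 2 `O=C(Nc1cc(C(F)(F)F)cc(C(F)(F)F)c1)c1cc(Br)ccc1O` share one core and differ by bromo in place of hydrogen on an aromatic carbon. In an ADME assay on cells (Macrophage, Mus musculus) for cytotoxicity, read by resazurin assay, with a stated time of 3 days (on this read-out lower numbers stand for stronger inhibition and higher numbers for weaker inhibition), compound 1 gives 12000 nM, and compound 2 gives 4900 nM, so that a 2.4-fold lower number from compound 1 to compound 2 (0.39 log units; beyond the scatter). Compound 3 `O=C(Nc1cc(F)cc(F)c1)c1cc(Cl)ccc1O` has a different core; the difference between the two cores is not broken down here. In this assay compound 3 gives 6100 nM. Compound 4 `O=C(Nc1cc(F)c(Br)c(F)c1)c1cc(Cl)ccc1O` is not yet measured and differs from compound 3 by bromo in place of hydrogen on an aromatic carbon. This is the same kind of change as the earlier one, not the same: there the bromo sat meta to a large group and para to a hydroxy group, here ortho to two fluoro groups and para to a large group. In this assay the step is expected to be a 2.0-fold lower number from compound 3 to compound 4 (0.31 log units; beyond the scatter), leaning on the earlier result because a 2.4-fold lower number from compound 1 to compound 2 (0.39 log units; beyond the scatter) was seen when bromo entered the core of compound 1. For compound 4 the estimate is 3000 nM, most likely between 1200 nM and 8000 nM.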

Compound 4, half-maximal inhibitory concentration: 4300 nM
Beside the measured number, compound 4's estimate is 1.4-fold (0.16 log units) below it; the measured number falls inside the stated range.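

In this assay, bromo in place of hydrogen on an aromatic carbon gives a 1.4-fold lower number from compound 3 to compound 4 (0.15 log units; within the scatter), so on this core the step cannot be told apart from the ordinary spread of repeated measurements. Set beside the step on the core of compound 1, it does not differ by more than that spread allows: the same change on two cores in this assay, a 2.4-fold lower number (0.39 log units; beyond the scatter) from compound 1 to compound 2 and a 1.4-fold lower number (0.15 log units; within the scatter) from compound 3 to compound 4, 1.7-fold (0.24 log units) apart, within the scatter of two such steps. Among the compounds shown here, this fits a change that carries over between the two cores but does not prove it, as each core offers only one pair, the bromo sits in a different place in each, and one of the two steps is within the scatter.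

The compounds shown leave open whether an amine or a carboxylic acid on the same aromatic carbon would give a step like that of bromo. They also leave open how bromo would behave on a third core.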